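The source may report more compounds than this note shows. Statements on the series, on what has been measured and on what is new or still open speak of the compounds shown alone.

Among the measured compounds shown here, compound 3 `C/C(=C\C(=O)Nc1ccccc1OCCCC(=O)O)c1ccc2c(ccn2Cc2ccc(C)cc2)c1` gives 88 nM in an assay on Prostate gland for inhibition of steroid 5-alpha-reductase (Rattus norvegicus) (a lower number here means a stronger inhibitor, a higher number a weaker inhibitor), the lowest of the three numbers so far, though both other numbers lie within the scatter of it: compound 1 `CCCCCCCn1ccc2cc(/C(C)=C/C(=O)Nc3ccccc3OCCCC(=O)O)ccc21` gives 120 nM and compound 2 `C/C(=C\C(=O)Nc1ccccc1OCCCC(=O)O)c1ccc2c(ccn2CC(C)C)c1` gives 160 nM. Compound 4 `C/C(=C\C(=O)Nc1ccccc1OCCCC(=O)O)c1ccc2c(ccn2C(CC(C)C)c2ccccc2)c1` differs from compound 3 by 3-methyl-1-phenylbutyl in place of 4-methylbenzyl on an aromatic nitrogen. All measured steps bear on this change, since each varies the same group on the aromatic nitrogen: a 1.4-fold lower number from compound 1 to compound 3 (0.13 log units; within the scatter), a 1.8-fold lower number from compound 2 to compound 3 (0.26 log units; within the scatter) and a 1.3-fold higher number from compound 1 to compound 2 (0.12 log units; within the scatter); none moved the number beyond the scatter. No step beyond the scatter is therefore expected for compound 4, a 1.0-fold higher number from compound 3 to compound 4 (0.01 log units; within the scatter). In this assay compound 4 is estimated at 90 nM, with a range from 40 nM to 220 nM.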

Compound 4, half-maximal inhibitory concentration: 6.3 nM
Beside the measured number, compound 4's estimate is 14-fold (1.15 log units) above it; the whole stated range lies above it.
By their numbers in this assay, from the lowest: compound 4; then compounds 3, 1 and 2 (each within the scatter of the next).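

In this assay, the substituent on the aromatic nitrogen is not a silent position: heptyl, isobutyl and 4-methylbenzyl stayed within the scatter of one another, yet 3-methyl-1-phenylbutyl gives a 14-fold lower number from compound 3 to compound 4 (1.15 log units; beyond the scatter), a 25-fold lower number from compound 2 to compound 4 (1.40 log units; beyond the scatter) and a 19-fold lower number from compound 1 to compound 4 (1.28 log units; beyond the scatter). The entering group carries both an aromatic ring and a branched chain on the carbon bound to the nitrogen, a combination absent from compounds 1, 2 and 3. No available measurement explains the gain. As far as these compounds go, it remains open whether the gain survives with a cyclohexyl in place of the phenyl, or with a methyl in place of the branched chain.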